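Chloro to Trifluoromethyl: What to Expect for Compound 4

A few compounds are considered here, and "the series" means these few. Any claim that something is new, unique, unknown or untested is made for them only; others in the source may bear on it.

Compound 1, `Cc1ccc(-c2cc(NC(=O)/C=C/c3ccc(Cl)cc3)n[nH]2)cc1`: 1520 nM in a functional assay on B16-F10 cells (Mus musculus) for antiproliferative activity, read by MTT assay, with a stated time of 48 h; a lower number here means a stronger inhibitor, a higher number a weaker inhibitor
Compound 2, `COc1ccc(/C=C/C(=O)Nc2cc(-c3ccc(Br)cc3)[nH]n2)cc1`: 770 nM
Compound 3, `O=C(/C=C/c1ccc(Cl)cc1)Nc1cc(-c2ccccc2)[nH]n1`: 1270 nM

Compound 1 gives the highest of the three numbers in this assay, yet it is not set apart from its companions. Among the compounds with values here, the one single-point step measured so far runs a 1.2-fold lower number from compound 1 to compound 3 (0.08 log units; within the scatter), and that is within the scatter. Compound 1 gives 1520 nM while compound 2 gives 770 nM, and the gap between those two values is also within the scatter, so the three compounds are best read as a cluster.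

Compound 4, `Cc1ccc(-c2cc(NC(=O)/C=C/c3ccc(C(F)(F)F)cc3)n[nH]2)cc1`, is the next member. The change from compound 1 is trifluoromethyl in place of chloro on an aromatic carbon. Within the data shown here, no measured step touches this position on the shared core; the only step available, from compound 1 to compound 3, concerns the other aromatic ring and was within the scatter. The data therefore give no reason to expect a shift in this assay beyond the scatter, in either direction.

Compound 4 is expected to land near its parent, at an estimated 1500 nM, with a range from 600 nM to 3800 nM. The expected step from the parent is a 1.0-fold lower number from compound 1 to compound 4 (0.01 log units; within the scatter), which is within the scatter.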

Compound 4, half-maximal inhibitory concentration: 1210 nM
Compound 4: the middle estimate sits 1.2-fold (0.09 log units) above what was measured; low and high end bracket the measured number.
By their numbers in this assay, from the lowest: compounds 2, 4, 3 and 1 (each within the scatter of the next).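

In this assay, within the data shown here, the step at this position reads a 1.3-fold lower number from compound 1 to compound 4 (0.10 log units; within the scatter), which gives the first direct look at the ring that carries the chloro group; the earlier step concerned only the other aromatic ring. Here, on an aromatic carbon para to a large group, 1 heavy atom gives way to 4 heavy atoms, and chloro and trifluoromethyl cannot be told apart in this assay, so this one exchange at this position leaves compound 4 in the same cluster as compound 1. No measurement available here explains this result.

Among these compounds, this is only one exchange between two groups, so it does not show whether the same position would accept a different kind of group, such as an amine, a carboxylic acid or a longer alkyl chain, or plain hydrogen in place of chloro. The compounds shown also leave open whether trifluoromethyl would behave the same way with the other aromatic ring changed, since compound 4 is compared here only with compound 1.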